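The source may report more compounds than this note shows. Statements on the series, on what has been measured and on what is new or still open speak of the compounds shown alone.

Measured compounds: compound 1 `O=C1C[C@H](NC(=O)[C@@H]2CN(C(=O)OCc3ccccc3)C[C@@H]3C/C=C\C[C@H](NC(=O)c4ccccc4)C(=O)N32)C(O)O1` with 125 nM; compound 2 `O=C1C[C@H](NC(=O)[C@@H]2CN(C(=O)Nc3ccccc3)C[C@@H]3CCCC[C@H](NC(=O)c4ccccc4)C(=O)N32)C(O)O1` with 1690 nM.

In a functional assay on THP-1 cells (Homo sapiens) for inhibition (a lower number here means a stronger inhibitor, a higher number a weaker inhibitor), compound 2 gives 1690 nM, the higher of the two numbers; the gap to compound 1, which in this assay gives 125 nM, lies beyond the scatter. Compound 3 `CN1C[C@@H]2CCCC[C@H](NC(=O)c3ccccc3)C(=O)N2[C@H](C(=O)N[C@H]2CC(=O)OC2O)C1` is not yet measured. It differs from compound 2 in one place: methyl in place of phenylcarbamoyl on an amine nitrogen in a ring. Within the data shown here, no measured pair shows this change. A modest loss is expected, with a 1.8-fold higher number from compound 2 to compound 3 (0.25 log units; within the scatter). Compound 3 is therefore estimated to give 3000 nM, within a range from 800 nM to 12000 nM.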

Compound 3, half-maximal inhibitory concentration: 1820 nM
The estimate for compound 3 lay 1.6-fold (0.22 log units) above the measured number; the range from low to high includes it.
By their numbers in this assay, from the lowest: compound 1; then compounds 2 and 3 (each within the scatter of the next).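

In this assay, putting methyl in place of phenylcarbamoyl on the amine nitrogen in the ring gives a 1.1-fold higher number from compound 2 to compound 3 (0.03 log units; within the scatter). At this position on the saturated core, the much smaller methyl therefore serves as well as the larger group with its six-membered aromatic ring. No available evidence accounts for this result.

On these data alone, whether an acetyl group or a longer chain on this nitrogen would give a different number remains open. Compound 1 differs from compound 2 and compound 3 in more than one place, so its lower number cannot be assigned to any single change.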